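Methyl in place of hydrogen on the five-membered ring

A few compounds are considered here, and "the series" means these few. Any claim that something is new, unique, unknown or untested is made for them only; others in the source may bear on it.

Compound 1 `COC(=O)[C@@]1(C)CCC=C2[C@@H]1CC[C@@H](C)[C@]2(C)Cc1c[nH]c2c(C)cccc12`, compound 2 `COC(=O)[C@@]1(C)CCC=C2[C@@H]1CC[C@@H](C)[C@]2(C)Cc1c[nH]c2c(Br)cccc12` and compound 3 `COC(=O)[C@@]1(C)CCC=C2[C@@H]1CC[C@@H](C)[C@]2(C)Cc1c[nH]c2c(Cl)cccc12` share one core and differ only in a single aromatic substituent. In a functional assay on A549 cells (Homo sapiens) for inhibition, read by sulforhodamine B assay, with a stated time of 48 h (a higher number here means a weaker inhibitor of growth, a lower number a stronger inhibitor of growth), compound 1 gives 11000 nM, compound 2 gives 22000 nM and compound 3 gives 22000 nM. The measured steps are a 2.0-fold higher number from compound 1 to compound 2 (0.30 log units; within the scatter), a 2.0-fold higher number from compound 1 to compound 3 (0.30 log units; within the scatter) and no change at the digits printed from compound 2 to compound 3 (within the scatter). Compound 2 thus stands level with compound 3 at the digits shown, the two together being the highest of the three numbers, with compound 1 the furthest away but still within the scatter.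

Compound 4 `COC(=O)[C@@]1(C)CCC=C2[C@@H]1CC[C@@H](C)[C@]2(C)Cc1c(C)[nH]c2c(Br)cccc12` differs from compound 2 by methyl in place of hydrogen on an aromatic carbon. Among the measured compounds shown here, none of the measured steps touches this position; all three concern the other aromatic carbon and all stay within the scatter, so they offer no direct precedent for this change in this assay. With nothing in the series pointing either way, the estimated step is no change at the digits printed from compound 2 to compound 4 (within the scatter), none beyond the scatter. Compound 4 is therefore expected near 22000 nM, within a range from 7000 nM to 70000 nM.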

Compound 4, concentration for 50% growth inhibition: 27000 nM
For compound 4 the middle estimate is 1.2-fold (0.09 log units) below the measured one; the measured number falls inside the stated range.
By their numbers in this assay, from the lowest: compounds 1, 2, 3 and 4 (each within the scatter of the next, the first and the last beyond it).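

In this assay, methyl in place of hydrogen on this aromatic carbon of the five-membered aromatic ring gives a 1.2-fold higher number from compound 2 to compound 4 (0.09 log units; within the scatter). Among the compounds shown here, this is the first reading at this position, as the earlier compounds vary only the other aromatic carbon, and it shows that, with bromo kept in place, a methyl here leaves compound 4 indistinguishable from compound 2 in this assay. No evidence is available on what lies behind this result.

Still open, as far as these compounds go, is whether the same methyl would behave alike in the setting of compound 1 or compound 3, where methyl or chloro replaces the bromo. Also open, from the compounds shown here alone, is whether a different group on this carbon, such as a longer chain, an amine or a carboxylic acid, would give a step beyond the scatter.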